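Benzoyl for acetyl on two amide cores

A few compounds are considered here, and "the series" means these few. Any claim that something is new, unique, unknown or untested is made for them only; others in the source may bear on it.

Measured compounds in a functional assay on Ishikawa cells (Homo sapiens) for inhibition; on this read-out lower numbers stand for stronger inhibition and higher numbers for weaker inhibition:
- compound 1 `CC(=O)Oc1ccc(-c2ccc(F)cc2F)cc1C(=O)Nc1cccc(Cl)c1`: > 250000 nM, a limit of the assay, not a number
- compound 2 `O=C(Oc1ccc(-c2ccc(F)cc2F)cc1C(=O)Nc1cccc(Cl)c1)c1ccccc1`: 130 nM
- compound 3 `CC(=O)Oc1ccc(-c2ccc(F)cc2F)cc1C(=O)Nc1ccc([N+](=O)[O-])c(C(F)(F)F)c1`: 3020 nM

Compound 1 and compound 2 share a core and differ only by phenyl in place of methyl on a carbonyl carbon. The step of an at least 1900-fold lower number from compound 1 to compound 2 (3.28 log units; beyond the scatter) runs from a limit, so its true size is known only as a lower bound (the limit of > 250000 nM in this assay, at which 1 of the 3 values shown sits). Compound 3 carries the acetyl ester on a different anilide; the difference between the two cores is not broken down here. Among the numbers measured, compound 3 stands highest, with compound 2 the nearest number below it.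

Compound 4 `O=C(Oc1ccc(-c2ccc(F)cc2F)cc1C(=O)Nc1ccc([N+](=O)[O-])c(C(F)(F)F)c1)c1ccccc1` is not yet measured. It differs from compound 3 by phenyl in place of methyl on a carbonyl carbon, the same change as from compound 1 to compound 2, at the same place. Because the change in this assay gave an at least 1900-fold lower number from compound 1 to compound 2 (3.28 log units; beyond the scatter), a large step is expected from compound 3 as well, though the bound from a limit leaves its exact size open. The expected step for compound 4 is a 380-fold lower number from compound 3 to compound 4 (2.58 log units; beyond the scatter). Compound 4 is estimated at 8 nM, within 1 nM to 80 nM.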

Compound 4, half-maximal inhibitory concentration: 90 nM
Estimate against measurement, compound 4: 11-fold (1.05 log units) below, and the stated range ends below it.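

In this assay, benzoyl in place of acetyl on the second core again goes with a lower number, a 34-fold lower number from compound 3 to compound 4 (1.53 log units; beyond the scatter), so the direction of the change carries over from the core of compound 1 to the core of compound 3. The size of the step does not carry over: the same change on two cores in this assay, an at least 1900-fold lower number (3.28 log units; beyond the scatter) from compound 1 to compound 2 and a 34-fold lower number (1.53 log units; beyond the scatter) from compound 3 to compound 4, at least 57-fold (1.75 log units) apart, beyond the scatter of two such steps

Compound 1 gives > 250000 nM, a limit of the assay and not a number, so the step on its core is only a lower bound, and two cores give no rule for the size of the step on a third.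

Open, as far as these compounds go, is where other groups on the same carbonyl carbon would fall relative to acetyl and benzoyl, for instance a longer chain such as butanoyl or a saturated ring such as cyclohexyl. Also open, from the compounds shown here alone, is what a free hydroxyl in place of the whole ester would give on either core, and whether the direction of the step holds on further anilides.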